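Methoxymethyl in place of tert-butyl: working notes on compound 3

A few compounds are considered here, and "the series" means these few. Any claim that something is new, unique, unknown or untested is made for them only; others in the source may bear on it.

In a functional assay on the whole organism (strain albino Sprague-Dawley) with Rattus norvegicus as the target, in the maximal electroshock model (a lower number here means that less compound is needed, a higher number that more compound is needed for the effect), compound 1 `CC(C)(C)[C@@H](N)C(=O)NCc1ccc(COc2cccc(F)c2)cc1` gives 30 mg/kg. Compound 2 `CC(C)(C)[C@@H](N)C(=O)NCc1ccc(C(F)(F)F)cc1` is reported only as a limit, < 30 mg/kg. Going by the values given here, compound 1 therefore holds the only actual number so far, and with a limit as its sole neighbour it cannot be placed in a ranking. Among the compounds with values here, the two measured compounds do not form a step that differs in one place, so no measured step bears directly on the next change.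

Compound 3 `COC[C@@H](N)C(=O)NCc1ccc(COc2cccc(F)c2)cc1` keeps the rest of compound 1 and carries this change: methoxymethyl in place of tert-butyl on a saturated chain carbon bound to an amine nitrogen and a carbonyl carbon. That is methoxymethyl in place of tert-butyl on a saturated chain carbon bound to an amine nitrogen and a carbonyl carbon.

With so little to go on, the expectation rests on compound 1 at 30 mg/kg alone, and no shift beyond the scatter in this assay is expected in either direction. The expected change is a 1.2-fold lower number from compound 1 to compound 3 (0.08 log units; within the scatter), small and with its direction unsettled. For compound 3 the estimated value is 25 mg/kg, with an expected range of 9 mg/kg to 70 mg/kg.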

Compound 3, dose for half-maximal effect: 12 mg/kg
Estimate against measurement, compound 3: 2.1-fold (0.32 log units) above; measured number inside the range.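

In this assay, the saturated chain carbon bound to an amine nitrogen and a carbonyl carbon now has its first readable step, with methoxymethyl in place of tert-butyl giving a 2.5-fold lower number from compound 1 to compound 3 (0.40 log units; beyond the scatter). On the core of compound 1, tert-butyl is therefore not required for the effect, and a group with one carbon fewer and one hydrogen-bond acceptor goes with less compound being needed, although this rests on a single pair. Nothing shown gives a cause for this step, which stands as an observation only.

Compound 2 remains a limit, < 30 mg/kg, and cannot be set against any number in the series. Open questions are whether the step carries over to the 4-trifluoromethyl-bearing core of compound 2, and how other groups at this carbon, such as hydroxymethyl, ethoxymethyl or a longer chain, would compare with methoxymethyl in this assay.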